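Methoxy to fluoro: what to expect of compound 4

The source may hold more compounds than are shown below. What is called first, only, known or untested is meant among the compounds shown, and "the series" means these compounds.

Measured in a functional assay on MGC-803 cells (Homo sapiens) for antiproliferative activity, read by MTT assay, with a stated time of 48 h; on this read-out higher numbers stand for weaker inhibition and lower numbers for stronger inhibition:
Compound 1 `COc1cc(N(Cc2ccc(C)cc2)C(=O)CSc2nc3ccccc3s2)cc(OC)c1OC`: 54200 nM
Compound 2 `COc1ccc(CN(C(=O)CSc2nc3ccccc3s2)c2cc(OC)c(OC)c(OC)c2)cc1N=[N+]=[N-]`: 187 nM
Compound 3 `COc1ccc(CN(C(=O)CSc2nc3ccccc3s2)c2cc(OC)c(OC)c(OC)c2)cc1OC`: 34100 nM

Compound 3 belongs with the high numbers, meaning weak inhibition. For the measured compounds named here, the gap inside that pair is small, a 1.6-fold lower number from compound 1 to compound 3 (0.20 log units; within the scatter), while the only low number lies far off, a 180-fold higher number from compound 2 to compound 3 (2.26 log units; beyond the scatter).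

Compound 4 `COc1ccc(CN(C(=O)CSc2nc3ccccc3s2)c2cc(OC)c(OC)c(OC)c2)cc1F` changes one place in compound 3: fluoro in place of methoxy on an aromatic carbon. This is fluoro in place of methoxy on an aromatic carbon, so 3,4-dimethoxyphenyl becomes 3-fluoro-4-methoxyphenyl.

Going by the values given here, the step most relevant here is the one already quoted between compound 2 and compound 3, which swaps a different group at this same carbon and is large. The second large step, a 290-fold lower number from compound 1 to compound 2 (2.46 log units; beyond the scatter), brings in the same azido group. So this carbon can matter a great deal, but no fluoro compound has been measured, and azido need not be a guide to fluoro. A moderate fall in this assay therefore seems likelier than a repeat of the azido gain, with no change also possible.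

The expected change is a 3.4-fold lower number from compound 3 to compound 4 (0.53 log units; beyond the scatter). For compound 4 the estimated value is 10000 nM, with an expected range of 1500 nM to 45000 nM.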

Compound 4, half-maximal inhibitory concentration: 416 nM
Estimate against measurement, compound 4: 24-fold (1.38 log units) above, and the stated range ends above it.
By their numbers in this assay, from the lowest: compound 2; then compound 4; then compounds 3 and 1 (each within the scatter of the next).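

In this assay, this aromatic carbon turns out to be sensitive to more than the azido group: with the rest of the molecule unchanged, replacing methoxy with fluoro gives a large step (an 82-fold lower number from compound 3 to compound 4 (1.91 log units; beyond the scatter)). Fluoro has only one heavy atom, yet it comes close to azido without fully matching it, since a modest step beyond the scatter remains (a 2.2-fold higher number from compound 2 to compound 4 (0.35 log units; beyond the scatter)), and so compound 2 is still the strongest inhibitor shown. The comparison with the 4-methylphenyl compound is also large (a 130-fold lower number from compound 1 to compound 4 (2.11 log units; beyond the scatter)), whereas the 3,4-dimethoxyphenyl of compound 3 stays within the scatter of that compound (a 1.6-fold lower number from compound 1 to compound 3 (0.20 log units; within the scatter)), so among these four compounds a 4-methoxy group gives a strong result only when azido or fluoro, not a second methoxy, occupies this carbon.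

The compounds shown leave open how a plain hydrogen, chloro, a nitrile or an amine at this carbon would compare with fluoro and azido. Nothing available here explains why methoxy and fluoro differ so widely at this carbon.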